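The source may report more compounds than this note shows. Statements on the series, on what has been measured and on what is new or still open speak of the compounds shown alone.

Measured compounds:
Compound 1, `Cc1cccc(-n2nncc2CN2C(=O)C3(C(C#N)=C(N)Oc4c3c3nc5ccccc5nc3c3ccccc43)c3ccccc32)c1`, in a functional assay on HepG2 cells (Homo sapiens) for antiproliferative activity, read by MTT assay, with a stated time of 48 h (a lower number here means a stronger inhibitor, a higher number a weaker inhibitor), compound 1 gives > 50000 nM, which is a limit of the assay and not a number.
Compound 2, `N#CC1=C(N)Oc2c(c3nc4ccccc4nc3c3ccccc23)C12C(=O)N(Cc1cnnn1-c1cccc(Cl)c1)c1ccccc12`, in this assay compound 2 gives > 50000 nM, again a limit of the assay.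
Compound 3, `N#CC1=C(N)Oc2c(c3nc4ccccc4nc3c3ccccc23)C12C(=O)N(Cc1cnnn1-c1ccc(S(N)(=O)=O)cc1)c1ccccc12`, in this assay compound 3 gives 42200 nM.

All three share one large core and differ only in the aryl group carried on the triazole nitrogen. Compound 2 stands at the limit; (the limit of > 50000 nM in this assay, at which 2 of the 3 values shown sit), so compound 2 cannot be ranked against compound 1, and the step that the two limits leave unreadable from compound 1 to compound 2. The step of an at least 1.1-fold lower number from compound 2 to compound 3 (0.07 log units; that floor lies within the scatter); the step of an at least 1.1-fold lower number from compound 1 to compound 3 (0.07 log units; that floor lies within the scatter).

The unmeasured compound 4, `Cc1ccc(C)c(-n2nncc2CN2C(=O)C3(C(C#N)=C(N)Oc4c3c3nc5ccccc5nc3c3ccccc43)c3ccccc32)c1`, differs from compound 2 at the same place: 2,5-dimethylphenyl in place of 3-chlorophenyl on an aromatic nitrogen. The two measured steps at this position, chloro in place of methyl and 4-sulfamoylphenyl in place of 3-chlorophenyl, moved the number by nothing that could be read beyond the scatter. A further change of the same kind is therefore expected to leave the number near where compound 2 sits, and the expected step of a number no higher from compound 2 to compound 4 (the limit leaves the size open) is no more than scatter.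

Compound 4 is expected to give about 50000 nM in this assay, within a range of 20000 nM to 200000 nM, most likely reported again as a limit.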

Compound 4, half-maximal inhibitory concentration: > 50000 nM
Compound 4 was reported as a limit; the forecaster's own chance of this, stated with the estimate: 75%; the middle value lies on the limit itself.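

Adding a methyl group to the aryl ring on the triazole nitrogen, which turns the 3-methylphenyl of compound 1 into the 2,5-dimethylphenyl of compound 4, brings no readable gain in this assay: compound 4 gives > 50000 nM, which is a limit of the assay and not a number. Among the compounds shown here, the steps to compound 4 from compound 1 and from compound 2 join two limits and cannot be read, and the one step that can be read is an at least 1.1-fold higher number from compound 3 to compound 4 (0.07 log units; that floor lies within the scatter). Among the aryl groups shown, only the 4-sulfamoylphenyl of compound 3 gives a number rather than a limit, and the others all sit at the same limit: the limit of > 50000 nM in this assay, at which 3 of the 4 values shown sit.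

All four compounds carry a substituted phenyl ring on the triazole nitrogen, with the shared core unchanged throughout. On these data alone, whether a phenyl ring bearing an amine or a carboxylic acid, or a longer alkyl chain in place of the ring, would bring the number down to a level where compounds can be ranked stays open.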